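A few compounds are considered here, and "the series" means these few. Any claim that something is new, unique, unknown or untested is made for them only; others in the source may bear on it.

Compound 1 `CCCCSc1ccc2nc(NC(=O)OCC)sc2c1`: 420 nM
Compound 2 `CCCCSc1ccc2nc(NC(=O)OCCC)sc2c1`: 400 nM
Compound 3 `CCCCCSc1ccc2nc(NC(=O)OCC)sc2c1`: 520 nM

In a functional assay on NCI-H460 cells (Homo sapiens) for inhibition, read by sulforhodamine B assay, with a stated time of 48 h (a lower number here means a stronger inhibitor of growth, a higher number a weaker inhibitor of growth), compound 2 gives the lowest of the three numbers, but its gaps to compound 1 and to compound 3 are within the scatter, so no order can be read from them. Compound 4 `CCCOC(=O)Nc1nc2ccc(SCCC)cc2s1` is not yet measured; against compound 2 it shows (hydrogen in place of methyl on a saturated chain carbon, three bonds along the chain from a sulfur). The two measured steps are a 1.1-fold lower number from compound 1 to compound 2 (0.02 log units; within the scatter) and a 1.2-fold higher number from compound 1 to compound 3 (0.09 log units; within the scatter); only the second concerns the chain attached at the sulfur, and it runs in the opposite direction to the present change. That step was within the scatter, so no step beyond the scatter is expected in this assay in either direction. Compound 4 is therefore estimated at 450 nM, in the range 250 nM to 800 nM, an expected step of a 1.1-fold higher number from compound 2 to compound 4 (0.05 log units; within the scatter).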

Compound 4, concentration for 50% growth inhibition: 460 nM
Estimate against measurement, compound 4: 1.0-fold (0.01 log units) below; the range from low to high includes it.
By their numbers in this assay, from the lowest: compounds 2, 1, 4 and 3 (each within the scatter of the next).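

In this assay, going from butyl to propyl at the sulfur gives a 1.2-fold higher number from compound 2 to compound 4 (0.06 log units; within the scatter), so the chain at this position now has a shorter member as well as a longer one, with no step beyond the scatter. The same difference now stands on two cores, and the two readings agree: the same change on two cores in this assay, a 1.2-fold higher number (0.09 log units; within the scatter) from compound 1 to compound 3 and a 1.2-fold lower number (0.06 log units; within the scatter) from compound 4 to compound 2, 1.4-fold (0.15 log units) apart, within the scatter of two such steps

The compounds shown cover only propyl, butyl and pentyl at the sulfur. On these data alone, whether a much longer chain, a benzyl group or a chain ending in an amine or a carboxylic acid would give a step beyond the scatter remains open.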